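A few compounds are considered here, and "the series" means these few. Any claim that something is new, unique, unknown or untested is made for them only; others in the source may bear on it.

Measured so far in a functional assay on HL-60 cells (Homo sapiens) for cytotoxicity, read by WST assay, with a stated time of 48 h (a lower number here means that less compound is needed, a higher number that more compound is needed for the effect), for three compounds:
compound 1 `CCCCOc1cccc(C[C@H]2C(=O)OC[C@@H]2Cc2ccccc2)c1` gives 26000 nM
compound 2 `O=C1OC[C@H](Cc2ccccc2)[C@H]1Cc1ccc(Cl)cc1Cl` gives 19000 nM
compound 3 `O=C1OC[C@H](Cc2ccccc2O)[C@H]1Cc1ccc(Cl)c(Cl)c1` gives 33000 nM

These three values lie within the usual scatter of one another, so compound 3 at 33000 nM cannot be separated from either compound 1 or compound 2 in this assay. Compound 4 `O=C1OC[C@H](Cc2ccc(O)cc2)[C@H]1Cc1ccc(Cl)c(Cl)c1` has not yet been measured. Compared with compound 3, it carries 4-hydroxyphenyl in place of 2-hydroxyphenyl on a saturated chain carbon bound to a saturated ring carbon and keeps the same atoms, joined differently.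

Among the measured compounds shown here, no two measured compounds differ in one place only, so the data give no direct measure of such a change. For the measured compounds named here, the only guide is the narrow spread of the three values, and no step beyond the scatter is expected. The estimated change is a 1.2-fold lower number from compound 3 to compound 4 (0.07 log units; within the scatter) and it is expected to stay within the scatter. For compound 4 the expected value is 28000 nM with an estimated range from 13000 nM to 60000 nM in this measurement.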

Compound 4, half-maximal effective concentration: 37000 nM
Estimate against measurement, compound 4: 1.3-fold (0.12 log units) below; the measured number falls inside the stated range.
By their numbers in this assay, from the lowest: compounds 2, 1, 3 and 4 (each within the scatter of the next).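

In this assay, putting 4-hydroxyphenyl in place of 2-hydroxyphenyl on a saturated chain carbon bound to a saturated ring carbon gives a 1.1-fold higher number from compound 3 to compound 4 (0.05 log units; within the scatter). Among the compounds shown here, this is the first direct comparison in which only one place differs, and it shows that the two hydroxyphenyl groups cannot be told apart at this position in this assay. Nothing at hand gives a measured reason for this result.

The compounds shown cover only these two hydroxyphenyl groups at this position, so they leave open whether an aminophenyl group, a carboxylic acid or a longer chain there would give a step beyond the scatter. They also leave open whether the same swap would give a similar result with a different group elsewhere on the shared core.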